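From 4-hydroxybenzyl to 2-fluorobenzyl on a shared core

This account rests on a few compounds, and the source may have more. Where it says the series, first, only, none or still open, it means among the compounds named here.

In a functional assay on Bel7402/5-FU cells (Homo sapiens) for antiproliferative activity, read by MTT assay, with a stated time of 72 h (on this read-out lower numbers stand for stronger inhibition and higher numbers for weaker inhibition), compound 1 `COc1cccc(CNCc2c(C(=O)O)n(Cc3ccc(O)cc3)c3cc(C(C)C)ccc23)c1` gives > 50000 nM, which is a limit and not a number. Compound 1 stands at the limit of > 50000 nM in this assay, at which 1 of the 3 values shown sits. Compound 2 `COc1ccc(Cn2c(C(=O)O)c(CN(C)Cc3cccc(OC)c3)c3ccc(C)cc32)cc1` gives 7470 nM, and compound 3 `COc1cccc(CNCc2c(C(=O)O)n(Cc3ccccc3)c3cc(C(C)C)ccc23)c1` gives 5920 nM.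

Compound 4 `COc1cccc(CNCc2c(C(=O)O)n(Cc3ccccc3F)c3cc(C(C)C)ccc23)c1` carries 2-fluorobenzyl in place of the 4-hydroxybenzyl of compound 1, on a saturated chain carbon bound to an aromatic nitrogen (2-fluorophenyl in place of 4-hydroxyphenyl on a saturated chain carbon bound to an aromatic nitrogen). The measured step that bears on this is hydrogen in place of hydroxy, an at least 8.4-fold lower number from compound 1 to compound 3 (0.92 log units; beyond the scatter). Compound 4 likewise has no hydroxy, so a step of similar size toward lower numbers is expected in this assay. No measurement shows what the fluorine adds. The expected step runs an at least 8.3-fold lower number from compound 1 to compound 4 (0.92 log units; beyond the scatter). Compound 4 is estimated at 6000 nM, with an expected range of 2200 nM to 18000 nM.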

Compound 4, half-maximal inhibitory concentration: 5210 nM
Compound 4: middle estimate off by 1.2-fold (0.06 log units), on the high side, within the range that was stated.
By their numbers in this assay, from the lowest: compounds 4, 3 and 2 (each within the scatter of the next). At a limit, above all of these: compound 1.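

Compound 1 stands at a limit and not at a number: the limit of > 50000 nM in this assay, at which 1 of the 4 values shown sits. Read against that limit, this assay shows an at least 9.5-fold lower number from compound 1 to compound 4 (0.98 log units; beyond the scatter), so the drop seen when the hydroxy is absent also holds with 2-fluorobenzyl on the saturated chain carbon bound to an aromatic nitrogen. Fluoro in place of hydrogen on an aromatic carbon gives a 1.1-fold lower number from compound 3 to compound 4 (0.06 log units; within the scatter), so the fluorine brings no change beyond the scatter.

Going by these compounds, it remains open how an amine or a chlorine on this benzyl ring would read. On these data alone, whether a longer chain in place of the benzyl carbon would keep these values is also open.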